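Benzoyl-ring substitution in a stilbene chalcone series

This account rests on a few compounds, and the source may have more. Where it says the series, first, only, none or still open, it means among the compounds named here.

Compound 1 `COc1ccc(/C=C/c2cc(OC)cc(OC)c2/C=C/C(=O)c2ccccc2)cc1` carries an unsubstituted benzoyl ring on the shared core; in a functional assay on HepG2 cells (Homo sapiens) for antiproliferative activity, read by MTT assay, with a stated time of 48 h (a lower number here means a stronger inhibitor, a higher number a weaker inhibitor), compound 1 gives 6.8 ug/mL, the lowest of the three numbers recorded so far, although neither neighbour is separated from it beyond the scatter. Compound 2 `COc1ccc(/C=C/c2cc(OC)cc(OC)c2/C=C/C(=O)c2cccc(Br)c2)cc1` gives 13 ug/mL and compound 3 `COc1ccc(/C=C/c2cc(OC)cc(OC)c2/C=C/C(=O)c2ccc(-c3ccccc3)cc2)cc1` gives 10.5 ug/mL. The two changes at the benzoyl ring that have been measured are a 1.9-fold higher number from compound 1 to compound 2 (0.28 log units; within the scatter) and a 1.5-fold higher number from compound 1 to compound 3 (0.19 log units; within the scatter); between those two products the step is a 1.2-fold lower number from compound 2 to compound 3 (0.09 log units; within the scatter). Every measured substitution on this ring has therefore left the number where it was, within the usual spread.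

Compound 4 `CCN(CC)c1ccc(C(=O)/C=C/c2c(/C=C/c3ccc(OC)cc3)cc(OC)cc2OC)cc1` differs from compound 1 in one place: diethylamino in place of hydrogen on an aromatic carbon. Among the measured compounds shown here, the steps that bear on it are those from compound 1 to compound 2 and from compound 1 to compound 3, both small and both within the scatter, so no step beyond the scatter is expected here either, with if anything a slight drift toward a higher number, as seen in both measured cases. Compound 4 is accordingly estimated at 8.5 ug/mL, with a range from 3.5 ug/mL to 20 ug/mL. That estimate corresponds to an expected step of a 1.3-fold higher number from compound 1 to compound 4 (0.10 log units; within the scatter).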

Compound 4, half-maximal inhibitory concentration: 6.3 ug/mL
The estimate for compound 4 lay 1.3-fold (0.13 log units) above the measured number; the range from low to high includes it.
By their numbers in this assay, from the lowest: compounds 4, 1, 3 and 2 (each within the scatter of the next, the first and the last beyond it).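

In this assay, diethylamino on an aromatic carbon, para to a large group, brings the first nitrogen substituent to this ring, yet a 1.1-fold lower number from compound 1 to compound 4 (0.03 log units; within the scatter) and a 1.7-fold lower number from compound 3 to compound 4 (0.22 log units; within the scatter), so among the compounds shown neither hydrogen, phenyl nor diethylamino at this place separates beyond the scatter. Among the compounds shown here, the one step that passes the scatter is a 2.1-fold lower number from compound 2 to compound 4 (0.31 log units; beyond the scatter), a modest one, and since 3-bromophenyl and 4-(diethylamino)phenyl differ in both the group and its place on the ring, it cannot be assigned to either difference alone. No measurement shown here offers an explanation for this flat response or for that single modest step.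

From the compounds shown here alone, whether a carboxylic acid or a primary amine at the place of the diethylamino would move the number beyond the scatter from compound 1 remains open, as does the effect of a longer chain on the nitrogen. Also open, going by these compounds, is whether bromo at that same place would give a number closer to compound 2 or to compound 4, which would separate the effect of the group from that of its place.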